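Pyrrolidinyl to Imidazolyl at the Chain Carbon: Compound 3

The source may hold more compounds than are shown below. What is called first, only, known or untested is meant among the compounds shown, and "the series" means these compounds.

Measured so far:
- compound 1 `CCN(CC)Cc1ccc(-c2ccnc3ccc(-c4cnc(OC)c(NS(=O)(=O)c5ccc(F)cc5F)c4)cc23)cc1` gives 5 nM in a functional assay on HCT-116 cells (Homo sapiens) for cytotoxicity, read by MTT assay, with a stated time of 72 h; a higher number here means a weaker inhibitor, a lower number a stronger inhibitor
- compound 2 `COc1ncc(-c2ccc3nccc(-c4ccc(CN5CCCC5)cc4)c3c2)cc1NS(=O)(=O)c1ccc(F)cc1F` gives 18.8 nM in this assay

For the measured compounds named here, compound 2 stands with the higher of the two numbers, separated from compound 1 by the only measured step, a 3.8-fold higher number from compound 1 to compound 2 (0.58 log units; beyond the scatter). Compound 3 `COc1ncc(-c2ccc3nccc(-c4ccc(Cn5ccnc5)cc4)c3c2)cc1NS(=O)(=O)c1ccc(F)cc1F` differs from compound 2 by 1H-imidazol-1-yl in place of pyrrolidin-1-yl on a saturated chain carbon bound to an aromatic carbon. Going by the values given here, no measured step covers this exchange; the step from compound 1 to compound 2 touches the same position, and it was modest. A further modest rise in this assay is therefore expected, a 2.7-fold higher number from compound 2 to compound 3 (0.42 log units; beyond the scatter). Compound 3 is estimated at 50 nM, with a range from 15 nM to 200 nM.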

Compound 3, half-maximal inhibitory concentration: 32.6 nM
Beside the measured number, compound 3's estimate is 1.5-fold (0.19 log units) above it; the measured number falls inside the stated range.
By their numbers in this assay, from the lowest: compound 1; then compounds 2 and 3 (each within the scatter of the next).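

In this assay, 1H-imidazol-1-yl in place of pyrrolidin-1-yl gives a 1.7-fold higher number from compound 2 to compound 3 (0.24 log units; within the scatter), so at this saturated chain carbon the aromatic and the non-aromatic five-membered ring are not told apart. In place of diethylamino, the same imidazole gives a 6.5-fold higher number from compound 1 to compound 3 (0.81 log units; beyond the scatter), which leaves compound 1 alone at the low end of the three. Nothing available bears on the reason for these numbers. Going by these compounds, whether a morpholine or a piperazine on this chain carbon would fall with compound 1 or with compound 2 and compound 3 remains open.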